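The source may hold more compounds than are shown below. What is called first, only, known or untested is meant among the compounds shown, and "the series" means these compounds.

Values in a functional assay on HeLa cells (Homo sapiens) for cytotoxicity, read by MTT assay, with a stated time of 48 h; on this read-out lower numbers stand for stronger inhibition and higher numbers for weaker inhibition:
Compound 1 `O=c1ccoc2cc(OCc3cn(Cc4cccc(Br)c4)nn3)ccc12`: > 100000 nM (a limit of the assay, not a number)
Compound 2 `O=c1ccoc2cc(OCc3cn(Cc4ccc(Cl)cc4Cl)nn3)ccc12`: 80600 nM
Compound 3 `O=c1ccoc2cc(OCc3cn(Cc4ccc(F)cc4)nn3)ccc12`: 12000 nM

For the measured compounds named here, compound 3 holds the lowest number so far. Going by the values given here, the only other exact value belongs to compound 2, at 80600 nM.

The next analogue is compound 4 `O=c1ccoc2cc(OCc3cn(Cc4ccccc4F)nn3)ccc12`. The change is 2-fluorophenyl in place of 4-fluorophenyl on a saturated chain carbon bound to an aromatic nitrogen. Among the compounds with values here, no measured step moves a fluorine on this ring, so the evidence is indirect. Three measured steps change the aryl group at this place: a 6.7-fold lower number from compound 2 to compound 3 (0.83 log units; beyond the scatter), an at least 8.3-fold lower number from compound 1 to compound 3 (0.92 log units; beyond the scatter) and an at least 1.2-fold lower number from compound 1 to compound 2 (0.09 log units; that floor lies within the scatter). The first two lie beyond the scatter, so the read-out can respond clearly to the aryl group here. Within the data shown here, both other aryl groups tested give higher numbers than the one in compound 3, which stands at 12000 nM.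

A move away from this low end is therefore expected, probably smaller than the measured steps, as only the fluorine changes place. The expected step is a 2.1-fold higher number from compound 3 to compound 4 (0.32 log units; beyond the scatter), towards weaker inhibition in this assay. For compound 4 the estimated value is 25000 nM, with an expected range of 8000 nM to 80000 nM.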

Compound 4, half-maximal inhibitory concentration: > 100000 nM
Compound 4: only a limit was reported; the forecaster's own chance of this, stated with the estimate: 15%; at least 4.0-fold (0.60 log units) between middle value and limit.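

In this assay compound 4 gives > 100000 nM, a limit of the assay and not a number. For the compounds shown here, the change from 4-fluorobenzyl to 2-fluorobenzyl keeps the same atoms, yet it gives an at least 8.3-fold higher number from compound 3 to compound 4 (0.92 log units; beyond the scatter), so at this place on a saturated chain carbon bound to an aromatic nitrogen the read-out responds to where the fluorine sits on the ring, whereas the earlier steps all changed the halogen as well. Against the dichlorinated analogue the result is an at least 1.2-fold higher number from compound 2 to compound 4 (0.09 log units; that floor lies within the scatter), so no order can be given for that pair, and the step between compound 1 and compound 4 cannot be read, as both values are limits.

The compounds shown leave open whether the lower number of compound 3 is specific to fluorine in the 4-fluorophenyl group or would persist with another group on the ring, such as an amine or a carboxylic acid, or with a longer chain in place of the single saturated carbon. How far the weakest analogues differ from one another also stays unresolved: the limit of > 100000 nM in this assay, at which 2 of the 4 values shown sit.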